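Styryl pyranone series: a third methoxy on compound 3

The source may report more compounds than this note shows. Statements on the series, on what has been measured and on what is new or still open speak of the compounds shown alone.

Compound 1 `O=c1ccoc(/C=C/c2ccccc2)c1` gives 514 uM in a functional assay on NCI/ADR cells (Homo sapiens) for inhibition, read by sulforhodamine B assay, with a stated time of 48 h; a higher number here means a weaker inhibitor of growth, a lower number a stronger inhibitor of growth. Compound 2 `COc1ccc(/C=C/c2cc(=O)cco2)cc1` gives 310 uM in this assay; its change from compound 1 is methoxy in place of hydrogen on an aromatic carbon, and the step is a 1.7-fold lower number from compound 1 to compound 2 (0.22 log units; within the scatter). Compound 3 `COc1cc(/C=C/C2CC=CC(=O)O2)cc(OC)c1` gives 8.9 uM in this assay, the lowest of the three numbers; the difference between its core and the core of compound 1 is not broken down here. Compound 4 `COc1cc(/C=C/C2CC=CC(=O)O2)cc(OC)c1OC` is not yet measured. Its change from compound 3 is methoxy in place of hydrogen on an aromatic carbon, the same kind of change as that from compound 1 to compound 2, though here the place is also ortho to two methoxy groups. The step expected from compound 3 to compound 4 is a 1.4-fold lower number from compound 3 to compound 4 (0.14 log units; within the scatter), a small move, because the earlier step of a 1.7-fold lower number from compound 1 to compound 2 (0.22 log units; within the scatter) stayed within the scatter. Compound 4 is therefore expected near 6.5 uM, between 2.5 uM and 20 uM.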

Compound 4, concentration for growth inhibition (reported as GI): 35.1 uM
Compound 4: the middle estimate sits 5.4-fold (0.73 log units) below what was measured; the measured number lies above the stated range.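

In this assay methoxy in place of hydrogen on an aromatic carbon gives a 3.9-fold higher number from compound 3 to compound 4 (0.60 log units; beyond the scatter). Set beside the earlier step, the change does not carry over unaltered from one core to the other: the same change on two cores in this assay, a 1.7-fold lower number (0.22 log units; within the scatter) from compound 1 to compound 2 and a 3.9-fold higher number (0.60 log units; beyond the scatter) from compound 3 to compound 4, 6.5-fold (0.82 log units) apart, beyond the scatter of two such steps

With a single pair on each core, and with the methoxy of compound 4 ortho to two methoxy groups, this does not show whether the core or those two groups accounts for the difference, and it gives no rule for other cores. Open, on these data alone, is whether a hydroxy group or an amine in that same place would move the number on the core of compound 3, and what a methoxy ortho to two methoxy groups would do on the core of compound 1.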